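The source may report more compounds than this note shows. Statements on the series, on what has been measured and on what is new or still open speak of the compounds shown alone.

In a physicochemical assay for solubility, read by spectrophotometry, in phosphate buffer, with a stated time of 18 h, at pH 7.4 (a higher number here means a more soluble compound, a lower number a less soluble compound), compound 3 `Cc1nn(-c2ccccc2)c2nc(-c3ccc(C#N)cc3)c(C#N)c(-c3ccccc3O)c12` gives 1700 nM and sits level, within the scatter, with compound 2 `Cc1nn(-c2ccccc2)c2nc(-c3ccc4ccccc4c3)c(C#N)c(-c3ccccc3O)c12` at 1800 nM while compound 1 `Cc1cccc(-c2nc3c(c(C)nn3-c3ccccc3)c(-c3ccccc3O)c2C#N)c1` reads 42000 nM far above both. Compound 4 `Cc1nn(-c2ccccc2)c2nc(-c3ccc4c(c3)CCCC4)c(C#N)c(-c3ccccc3O)c12` is unmeasured and differs from compound 3 in one place 1,2,3,4-tetrahydronaphthalen-6-yl in place of 4-cyanophenyl on an aromatic carbon on the aromatic carbon next to the ring nitrogen. Two large steps lead away from the 3-methylphenyl group of compound 1, namely a 23-fold lower number from compound 1 to compound 2 (1.37 log units; beyond the scatter) and a 25-fold lower number from compound 1 to compound 3 (1.39 log units; beyond the scatter) as well. Exchanging the two groups that replaced it gave only a 1.1-fold lower number from compound 2 to compound 3 (0.02 log units; within the scatter) within the scatter. The entering group has two rings, as the naphthalen-2-yl group of compound 2 does by its name, so no step beyond the scatter is expected in this assay here. Compound 4 is expected near 1900 nM with 500 nM to 7000 nM as the estimated range. That estimate means an expected 1.1-fold higher number from compound 3 to compound 4 (0.05 log units; within the scatter) overall.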

Compound 4, solubility: 13000 nM
The estimate for compound 4 lay 6.8-fold (0.84 log units) below the measured number, and the stated range ends below it.
By their numbers in this assay, from the lowest: compounds 3 and 2 (each within the scatter of the next); then compound 4; then compound 1.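

In this assay the 1,2,3,4-tetrahydronaphthalen-6-yl group gives a 7.2-fold higher number from compound 2 to compound 4 (0.86 log units; beyond the scatter) when it replaces naphthalen-2-yl, so at this position having two rings does not by itself fix the number. It also gives a 7.6-fold higher number from compound 3 to compound 4 (0.88 log units; beyond the scatter) and a 3.2-fold lower number from compound 1 to compound 4 (0.51 log units; beyond the scatter) and thus adds a middle level to the high and low levels seen before. Nothing measured here explains these differences. Still open, going by these compounds, is how a phenyl ring carrying an amine or a carboxylic acid would read at this position, or a cyclohexyl group with no aromatic ring.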